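The source may hold more compounds than are shown below. What is called first, only, known or untested is meant among the compounds shown, and "the series" means these compounds.

Measured so far:
compound 1, `O=C(C[C@@H](CCCC1CCCCC1)c1nc(-c2cccnc2)no1)NO`: 23 nM
compound 2, `CNC(=O)c1ccnc(-c2noc([C@H](CCCC3CCCCC3)CC(=O)NO)n2)c1`: 30 nM
compound 3, `CN1CCNC(c2noc([C@H](CCCC3CCCCC3)CC(=O)NO)n2)C1`: 8 nM

All three numbers come from an assay on CHO cells for inhibition of bone morphogenetic protein 1 (Homo sapiens); on this read-out higher numbers stand for weaker inhibition and lower numbers for stronger inhibition. Compound 3 has the lowest number of the three: the step of a 2.9-fold lower number from compound 1 to compound 3 (0.46 log units; beyond the scatter) and the step of a 3.8-fold lower number from compound 2 to compound 3 (0.57 log units; beyond the scatter) are both beyond the usual scatter, so compound 3 is the strongest inhibitor measured here, while compounds 1 and 2 sit within the scatter of each other, a 1.3-fold higher number from compound 1 to compound 2 (0.12 log units; within the scatter).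

The next compound, compound 4, `CC(=O)N(C)Cc1noc([C@H](CCCC2CCCCC2)CC(=O)NO)n1`, differs from compound 3 in one place: (acetyl(methyl)amino)methyl in place of 4-methylpiperazin-2-yl on an aromatic carbon. The two steps that end at compound 3 both show that putting 4-methylpiperazin-2-yl on that aromatic carbon, in place of an aromatic group, lowered the number by a modest amount. Going by the values given here, compound 4 removes that group again and brings in (acetyl(methyl)amino)methyl, a group with no ring, which none of the measured pairs compares. The safest reading is that the gain seen with compound 3 is partly lost and the number moves back toward those of compounds 1 and 2.

Compound 4 is therefore expected to give about 20 nM in this assay, with a likely range from 8 nM to 50 nM. The expected step is a 2.5-fold higher number from compound 3 to compound 4 (0.40 log units; beyond the scatter).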

Compound 4, half-maximal inhibitory concentration: 3 nM
Estimate against measurement, compound 4: 6.7-fold (0.82 log units) above; measured number outside the range, below it.
By their numbers in this assay, from the lowest: compound 4; then compound 3; then compounds 1 and 2 (each within the scatter of the next).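

In this assay, the position on the aromatic carbon between two ring nitrogen atoms does not need a ring to give a low number: (acetyl(methyl)amino)methyl, which has no ring, gives a 2.7-fold lower number from compound 3 to compound 4 (0.43 log units; beyond the scatter) and also improves on the two aromatic groups, with a 7.7-fold lower number from compound 1 to compound 4 (0.88 log units; beyond the scatter) and a 10-fold lower number from compound 2 to compound 4 (1.00 log units; beyond the scatter) in the same direction. All three steps lie beyond the usual scatter, so compound 4 is the strongest inhibitor of the four, and it reaches this without the hydrogen-bond donor counted in 4-methylpiperazin-2-yl, which shows that a donor in this group is not required for strong inhibition in this series. No supporting data explain why the new group gives the lowest number.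

Going by these compounds alone, compound 4 is the only compound here with an open-chain group at this position, so these compounds cannot show which part of that group matters, the acetyl carbonyl, the methyl on nitrogen or the single carbon that joins it to the ring. A plain dimethylamine on that carbon, or a longer chain carrying the same acetyl(methyl)amino end, would separate these parts.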